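Hydroxy for formyl in the aryl chloro nitro sulfone series

The compounds below may be only part of what the source reports. "The series", "measured", "known", "first", "only" and "open" are said of these compounds alone.

Measured in an ADME assay on HepG2 cells (Homo sapiens) for cytotoxicity, read by MTT assay, with a stated time of 72 h (a lower number here means that less compound is tolerated, a higher number that more compound is tolerated), so far:
compound 1 `COc1ccc(-c2cc(Cl)cn3c([N+](=O)[O-])c(CS(=O)(=O)c4ccccc4)nc23)cc1` gives > 3900 nM (a limit)
compound 2 `N#Cc1ccc(-c2cc(Cl)cn3c([N+](=O)[O-])c(CS(=O)(=O)c4ccccc4)nc23)cc1` gives > 3900 nM (a limit)
compound 3 `O=Cc1ccc(-c2cc(Cl)cn3c([N+](=O)[O-])c(CS(=O)(=O)c4ccccc4)nc23)cc1` gives > 31200 nM (a limit)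

Compound 3 gives only a limit (> 31200 nM). Compound 1 and compound 2 stand at the other limit (the limit of > 3900 nM in this assay, at which 2 of the 3 values shown sit).

Compound 4 `O=[N+]([O-])c1c(CS(=O)(=O)c2ccccc2)nc2c(-c3ccc(O)cc3)cc(Cl)cn12` has not been measured. It carries hydroxy in place of formyl on an aromatic carbon, para to a large group (hydroxy in place of formyl on an aromatic carbon).

Two measured steps end at formyl (a step that the two limits leave unreadable from compound 1 to compound 3; a step that the two limits leave unreadable from compound 2 to compound 3), and a third does not involve it (a step that the two limits leave unreadable from compound 1 to compound 2). None of the three has a readable size, so none offers a size to carry over. The closest measured neighbour is compound 1, with methoxy at that place, and its entry is a limit (> 3900 nM).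

In this assay the expected step is only a rough estimate (an at least 2.0-fold lower number from compound 3 to compound 4 (0.31 log units; beyond the scatter)), leaning towards a lower number, and a report as a limit alone is likely. The estimate for compound 4 is 15000 nM (expected range 3900 nM to 40000 nM).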

Compound 4, half-maximal cytotoxic concentration: > 12500 nM
Compound 4 gave a limit, no number; the forecaster's own chance of this, stated with the estimate: 80%; the middle value is on the limit's open side.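

In this assay compound 4 gives > 12500 nM, which is a limit and not a number. Among the compounds shown here, compound 1, compound 2 and compound 3 also stand at limits, and no step from any of them to compound 4 can be read. The compounds shown leave open the half-maximal cytotoxic concentration of all four, and whether methoxy, cyano, formyl and hydroxy differ at all in this assay.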